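Removing the acyl group from compound 2

The compounds below may be only part of what the source reports. "The series", "measured", "known", "first", "only" and "open" are said of these compounds alone.

- Compound 1 `COc1ccc(CNc2cc(OC)c(OC)c(OC)c2)cc1Br` gives 29400 nM in the assay below
- Compound 2 `C/C=C/C(=O)N(Cc1ccc(OC)c(N)c1)c1cc(OC)c(OC)c(OC)c1` gives 150 nM in the assay below

Both compounds were tested in a functional assay on MGC-803 cells (Homo sapiens) for inhibition, read by MTT assay, with a stated time of 48 h (a lower number here means a stronger inhibitor, a higher number a weaker inhibitor), and compound 2 holds the lower of the two numbers. Compound 1 stands higher by a margin beyond the scatter, so compound 2 is the stronger inhibitor of this pair.

The next compound to be measured is compound 3 `COc1ccc(CNc2cc(OC)c(OC)c(OC)c2)cc1N` and it differs from compound 2 by hydrogen in place of (prop-1-en-1-yl)carbonyl on a nitrogen on an aromatic ring in one place. It has hydrogen in place of (prop-1-en-1-yl)carbonyl on a nitrogen on an aromatic ring. Going by the values given here, no measured pair isolates this change, so the data give no direct size for it. The only hint is loose, since compound 1 also lacks that carbonyl group but carries a bromine where compound 3 has an amino group. With compound 1 at 29400 nM in this assay as that hint, a large move toward a higher number is expected, beyond the scatter and probably stopping short of compound 1.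

The expected change is a 20-fold higher number from compound 2 to compound 3 (1.30 log units; beyond the scatter) in this assay. Compound 3 is estimated at 3000 nM within an expected range of 600 nM to 15000 nM in this assay.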

Compound 3, half-maximal inhibitory concentration: 7970 nM
Compound 3: the middle estimate sits 2.7-fold (0.42 log units) below what was measured, and the stated range covers the measured number.
By their numbers in this assay, from the lowest: compound 2; then compound 3; then compound 1.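

In this assay the acyl group now has a measured size: a 53-fold higher number from compound 2 to compound 3 (1.73 log units; beyond the scatter) when hydrogen replaces (prop-1-en-1-yl)carbonyl on the nitrogen on an aromatic ring, so the much lower number of compound 2 depends strongly on this acyl group within this pair. Going by these compounds alone, compound 3 also gives the first reading of the other changed place, with a 3.7-fold lower number from compound 1 to compound 3 (0.57 log units; beyond the scatter) for amino in place of bromo on an aromatic carbon, a modest step beside the large one, and with the acyl group absent from both compounds. Nothing available accounts for either step.

As far as these compounds go, it remains open whether the low number of compound 2 needs the (prop-1-en-1-yl)carbonyl group itself, or whether an acetyl group or a saturated butanoyl group on the same nitrogen would keep it or fall back toward compound 3. Also open, from the compounds shown here alone, is how amino and bromo compare when the acyl group stays in place, and whether a hydroxyl group on that aromatic carbon would fit the same order.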